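Removing the trifluorobutoxy chain from compound 2

The source may hold more compounds than are shown below. What is called first, only, known or untested is meant among the compounds shown, and "the series" means these compounds.

compound 1 `Oc1nc2nonc2nc1Nc1ccc(OCCCC(F)(F)F)c(F)c1`: 4200 nM in an assay on mitochondria from L6 cells (Rattus norvegicus) for activation, with a stated time of 90 min; a lower number here means that less compound is needed, a higher number that more compound is needed for the effect
compound 2 `Oc1nc2nonc2nc1Nc1ccc(OCCCC(F)(F)F)c(C(F)(F)F)c1`: 2100 nM in this assay

Among the measured compounds shown here, compound 2 holds the lowest of the two numbers in this assay, and the single measured step, a 2.0-fold lower number from compound 1 to compound 2 (0.30 log units; within the scatter), leads to it. Compound 3 `Oc1nc2nonc2nc1Nc1cccc(C(F)(F)F)c1` differs from compound 2 by hydrogen in place of 4,4,4-trifluorobutoxy on an aromatic carbon. For the measured compounds named here, no measured step touches this chain; the one step on record concerns a different substituent and lies within the scatter, so it does not bear on the change. With the whole chain gone, a higher number is expected for compound 3, its size uncertain. Compound 3 is estimated at 7000 nM, range 1500 nM to 30000 nM, which is expected to mean a 3.3-fold higher number from compound 2 to compound 3 (0.52 log units; beyond the scatter).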

Compound 3, half-maximal effective concentration: 13300 nM
Beside the measured number, compound 3's estimate is 1.9-fold (0.28 log units) below it; the range from low to high includes it.
By their numbers in this assay, from the lowest: compounds 2 and 1 (each within the scatter of the next); then compound 3.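

Among the compounds shown here, replacing the 4,4,4-trifluorobutoxy chain with hydrogen gives a 6.3-fold higher number from compound 2 to compound 3 (0.80 log units; beyond the scatter) in this assay, the first step to lie beyond the scatter. The loss of the chain thus registers in this assay, while compound 3, even without it, still gives a measured number, so the chain is not required for a response. Nothing on hand explains the change. The compounds shown leave open whether the difference follows the chain's oxygen, its fluorines or its length. They also leave open how a methoxy group, a plain butoxy chain or an amine would stand on this carbon.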